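From an Amino Group to a Silicon Group

This account rests on a few compounds, and the source may have more. Where it says the series, first, only, none or still open, it means among the compounds named here.

Measured in a functional assay on SMMC-7721 cells (Homo sapiens) for antiproliferative activity, read by MTT assay, with a stated time of 48 h; a higher number here means a weaker inhibitor, a lower number a stronger inhibitor:
- compound 1 `CC(C)=CCC[C@]1(C)/C=C/[C@@H](OC(=O)C=C(C)C)[C@](C)(O)/C=C/C(=O)/C(CCl)=C\C1`: 840 nM
- compound 2 `CCN(CC)C/C1=C/C[C@](C)(CCC=C(C)C)/C=C/[C@@H](OC(=O)C=C(C)C)[C@](C)(O)/C=C/C1=O`: 570 nM
- compound 3 `CC(C)=CCC[C@]1(C)/C=C/[C@@H](OC(=O)C=C(C)C)[C@](C)(O)/C=C/C(=O)/C(CN(C(C)C)C(C)C)=C\C1`: 340 nM

Compound 3 stands clear of compound 1, with a 2.5-fold lower number from compound 1 to compound 3 (0.39 log units; beyond the scatter). It cannot be separated from compound 2, since the data show a 1.7-fold lower number from compound 2 to compound 3 (0.22 log units; within the scatter). The next compound, compound 4 `CC(C)=CCC[C@]1(C)/C=C/[C@@H](OC(=O)C=C(C)C)[C@](C)(O)/C=C/C(=O)/C(C[Si](C)(C)C(C)(C)C)=C\C1`, keeps the core of compound 3 and changes one group: a group of 7 heavy atoms (6 carbon, 1 silicon; no ring) in place of a group of 7 heavy atoms (6 carbon, 1 nitrogen; no ring), on a saturated chain carbon bound to a double-bonded ring carbon. The change lies on a saturated chain carbon bound to a double-bonded ring carbon, and the entering group has no nitrogen.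

For the measured compounds named here, no measured compound carries silicon, so the evidence is indirect. All three measured steps concern this same place. Besides the two steps above, the data show a 1.5-fold lower number from compound 1 to compound 2 (0.17 log units; within the scatter). Swapping one amino group for another thus moved the number little, and replacing chloro with an amino group moved it modestly at most. Going by the values given here, compound 1, the only measured compound without an amino group here, gives 840 nM, which suggests a drift upward once the amino group leaves. In this assay, the expected change is a 1.6-fold higher number from compound 3 to compound 4 (0.22 log units; within the scatter), so a small move toward a higher number is expected rather than a clear step. The estimated value for compound 4 is 560 nM, with an expected range of 200 nM to 1500 nM.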

Compound 4, half-maximal inhibitory concentration: 4000 nM
Compound 4: the middle estimate sits 7.1-fold (0.85 log units) below what was measured; the whole stated range lies below it.
By their numbers in this assay, from the lowest: compounds 3, 2 and 1 (each within the scatter of the next, the first and the last beyond it); then compound 4.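

At this saturated chain carbon, chloro, diethylamino and diisopropylamino had kept the numbers in a fairly narrow band in this assay, but the silicon group of compound 4 brings the first large step: a 12-fold higher number from compound 3 to compound 4 (1.07 log units; beyond the scatter). The rise is not confined to the comparison with diisopropylamino, as the data also show a 7.0-fold higher number from compound 2 to compound 4 (0.85 log units; beyond the scatter) and a 4.8-fold higher number from compound 1 to compound 4 (0.68 log units; beyond the scatter); the last of these matters most, since chloro also has no nitrogen, so the absence of nitrogen alone does not set the number at this place. The compounds shown include no measurement that explains why the silicon group gives so much higher a number.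

For the compounds shown here, whether the silicon atom itself matters remains open, since the set has no counterpart with a carbon atom in its place, nor a smaller silicon group such as trimethylsilyl. The amine side is also thinly explored, with only two open-chain dialkylamino groups shown, so a cyclic amine such as piperidine or morpholine might or might not follow them in this assay.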